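Aryl variation on the shared core: outlook for compound 3

The compounds below may be only part of what the source reports. "The series", "measured", "known", "first", "only" and "open" are said of these compounds alone.

Compound 1 `CCOC(=O)c1cnn(-c2nc(-c3ccc(OC)cc3)c(C#N)c(=O)n2C)c1N` — a functional assay, with a stated time of 20 min; a higher number here means a weaker inhibitor, a lower number a stronger inhibitor: 59 ug/mL
Compound 2 `CCOC(=O)c1cnn(-c2nc(-c3ccccc3F)c(C#N)c(=O)n2C)c1N` — this assay: 69 ug/mL

Among the measured compounds shown here, compound 2 stands at the higher of the two numbers so far, but its only neighbour, compound 1, sits within the scatter of it: a 1.2-fold higher number from compound 1 to compound 2 (0.07 log units; within the scatter). Compound 3 `CCOC(=O)c1cnn(-c2nc(-c3cccc(OC)c3OC)c(C#N)c(=O)n2C)c1N` differs from compound 2 in one place: 2,3-dimethoxyphenyl in place of 2-fluorophenyl on an aromatic carbon. For the measured compounds named here, the one measured step, a 1.2-fold higher number from compound 1 to compound 2 (0.07 log units; within the scatter), also exchanges the aryl group at this carbon and stays within the scatter, so it gives no basis for a move in either direction. The expected step is therefore a 1.2-fold lower number from compound 2 to compound 3 (0.06 log units; within the scatter), none beyond the scatter. Compound 3 is estimated at 60 ug/mL, with a range of 30 ug/mL to 120 ug/mL.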

Compound 3, half-maximal inhibitory concentration: 54 ug/mL
Compound 3: the middle estimate sits 1.1-fold (0.05 log units) above what was measured; low and high end bracket the measured number.
By their numbers in this assay, from the lowest: compounds 3, 1 and 2 (each within the scatter of the next).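

In this assay, 2,3-dimethoxyphenyl at this aromatic carbon reads level with 2-fluorophenyl (a 1.3-fold lower number from compound 2 to compound 3 (0.11 log units; within the scatter)) and with 4-methoxyphenyl (a 1.1-fold lower number from compound 1 to compound 3 (0.04 log units; within the scatter)). All three aryl groups now lie within the scatter of one another, so adding a second methoxy group to the ring does not separate them. Nothing available explains this flat reading. As far as these compounds go, whether a non-aromatic group at this carbon, such as an amine or a longer alkyl chain, would give a step beyond the scatter remains open. So does the effect of an aryl group bearing a carboxylic acid.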